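This account rests on a few compounds, and the source may have more. Where it says the series, first, only, none or still open, it means among the compounds named here.

Measured so far in an assay on CHO cells for antagonist activity at transient receptor potential cation channel subfamily V member 1 (Homo sapiens), read by FLIPR and calcium flux; a higher number here means a weaker inhibitor, a lower number a stronger inhibitor:

Compound 1, `CCC1CCC(c2nc(C(F)(F)F)ccc2CNC(=O)C(C)c2ccc(NS(C)(=O)=O)c(F)c2)CC1`: 0.3 nM
Compound 2, `CC(C(=O)NCc1ccc(C(F)(F)F)nc1C1CC2CCC1C2)c1ccc(NS(C)(=O)=O)c(F)c1`: 1.5 nM
Compound 3, `CC(C(=O)NCc1ccc(C(F)(F)F)nc1C1=CCCCC1)c1ccc(NS(C)(=O)=O)c(F)c1`: 0.7 nM

Compound 3 stands second highest of the three numbers in this assay. Its nearest neighbour is compound 2, with the step of a 2.1-fold lower number from compound 2 to compound 3 (0.33 log units; beyond the scatter); its furthest is compound 1, with the step of a 2.3-fold higher number from compound 1 to compound 3 (0.37 log units; beyond the scatter). All three compounds share one core and differ only in the saturated or partly saturated group on the aromatic carbon next to the ring nitrogen.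

Compound 4, `CCC/C=C/c1nc(C(F)(F)F)ccc1CNC(=O)C(C)c1ccc(NS(C)(=O)=O)c(F)c1`, is not yet measured. It differs from compound 3 by pent-1-en-1-yl in place of cyclohex-1-en-1-yl on an aromatic carbon, so the ring is opened into a chain of the same kind of unsaturation.

The measured steps that bear on this are those changing the same group: a 5.0-fold higher number from compound 1 to compound 2 (0.70 log units; beyond the scatter) and a 2.3-fold higher number from compound 1 to compound 3 (0.37 log units; beyond the scatter) both gave modestly higher numbers when the 4-ethylcyclohexyl group was replaced by a smaller group, while a 2.1-fold lower number from compound 2 to compound 3 (0.33 log units; beyond the scatter) showed a modest move the other way. None of these removes the ring entirely, so the direct precedent is thin. A modest step upward is therefore expected, roughly a 2.1-fold higher number from compound 3 to compound 4 (0.33 log units; beyond the scatter), and compound 4 is expected to give about 1.5 nM, within 0.5 nM to 5 nM.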

Compound 4, inhibition constant: 0.9 nM
For compound 4 the middle estimate is 1.7-fold (0.22 log units) above the measured one; the range from low to high includes it.
By their numbers in this assay, from the lowest: compound 1; then compounds 3, 4 and 2 (each within the scatter of the next, the first and the last beyond it).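

In this assay, opening cyclohex-1-en-1-yl into pent-1-en-1-yl on this aromatic carbon next to the ring nitrogen leaves the reading within the scatter (a 1.3-fold higher number from compound 3 to compound 4 (0.11 log units; within the scatter)), so among these compounds a ring at this position is not required for a low number. The chain also lies within the scatter of the group with two five-membered rings (a 1.7-fold lower number from compound 2 to compound 4 (0.22 log units; within the scatter)), and only the 4-ethylcyclohexyl group remains apart from it (a 3.0-fold higher number from compound 1 to compound 4 (0.48 log units; beyond the scatter)). No measurement offered here accounts for these readings.

The compounds shown leave open whether the double bond of the chain matters, as a saturated pentyl chain is not among them. They also leave open how a shorter propenyl chain, a longer heptenyl chain or an amine at this position would read in this assay.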